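The compounds below may be only part of what the source reports. "The series", "measured", "known", "first", "only" and "open" are said of these compounds alone.

Measured so far:
- compound 1 `COc1ccc(Cn2ncc3c2NC(=O)CC(c2cccc(NC(=O)Nc4ccc(Cl)cc4)c2)=N3)cc1`: 580 nM
- compound 2 `COc1ccc(Cn2ncc3c2NC(=O)CC(c2cccc(NC(=O)Nc4ccc(Cl)c(Cl)c4)c2)=N3)cc1`: 14900 nM

In a functional assay on U-937 cells (Homo sapiens) for inhibition, read by MTT assay, with a stated time of 24 h (on this read-out higher numbers stand for weaker inhibition of growth and lower numbers for stronger inhibition of growth), compound 2 stands at the higher of the two numbers, 14900 nM, so it is the weaker inhibitor of the pair. Next is compound 3 `COc1ccc(Cn2ncc3c2NC(=O)CC(c2cccc(NC(=O)Nc4cccc(C(F)(F)F)c4)c2)=N3)cc1`, with this change: 3-(trifluoromethyl)phenyl in place of 3,4-dichlorophenyl on an amide-type nitrogen. In words, 3-(trifluoromethyl)phenyl replaces 3,4-dichlorophenyl on an amide-type nitrogen.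

Among the compounds with values here, one measured step bears on this: a 26-fold higher number from compound 1 to compound 2 (1.41 log units; beyond the scatter), where chloro replaced hydrogen on an aromatic carbon of the same ring. Within the data shown here, no measured compound carries trifluoromethyl, so that step transfers only loosely. A moderate to large move toward a lower number in this assay is expected, probably smaller than that step. The expected change is a 5.0-fold lower number from compound 2 to compound 3 (0.70 log units; beyond the scatter). The estimate for compound 3 is 3000 nM, with an expected range of 600 nM to 14000 nM.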

Compound 3, concentration for 50% growth inhibition: 280 nM
Estimate against measurement, compound 3: 11-fold (1.03 log units) above; the measured number lies below the stated range.
By their numbers in this assay, from the lowest: compound 3; then compound 1; then compound 2.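

In this assay, the group on the amide-type nitrogen has a large effect: 3-(trifluoromethyl)phenyl in place of 3,4-dichlorophenyl gives a 53-fold lower number from compound 2 to compound 3 (1.73 log units; beyond the scatter), which more than cancels the loss seen with the second chloro. Against 4-chlorophenyl, the same group gives only a 2.1-fold lower number from compound 1 to compound 3 (0.32 log units; beyond the scatter), a modest step but beyond the scatter, leaving compound 3 as the strongest of the three inhibitors of growth. The entering group has more heavy atoms than 3,4-dichlorophenyl, so a larger group here does not by itself weaken inhibition, at least in this pair; no measurement shown accounts for the differences among these compounds.

Open, as far as these compounds go, is how this nitrogen responds to substituents without halogen, such as a methoxyphenyl, a cyanophenyl or a saturated cyclohexyl ring. Also open, from the compounds shown here alone, is whether this order of the three compounds holds in other cell lines or at other exposure times.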